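This account rests on a few compounds, and the source may have more. Where it says the series, first, only, none or still open, it means among the compounds named here.

Compound 1 `CNC(=O)c1oc2nc(-c3ccccc3)cc(C(F)(F)F)c2c1N` gives 62000 nM in an ADME assay on HEK293 cells (Homo sapiens) for antiproliferative activity, read by MTT assay; a higher number here means a weaker inhibitor, a lower number a stronger inhibitor.
Compound 2 `CNC(=O)c1oc2nc(-c3cccs3)cc(C(F)(F)F)c2c1N` gives 75000 nM in this assay.
Compound 3 `Nc1c(C(=O)N/N=C/c2ccc(Cl)cc2)oc2nc(-c3ccccc3)cc(C(F)(F)F)c12` gives 81000 nM in this assay.

These three compounds share a core and differ at two places: the aromatic group attached to the core, and the group on the amide-type nitrogen. Compound 2 stands second highest of the three numbers, but all three lie within the scatter of one another: a 1.2-fold higher number from compound 1 to compound 2 (0.08 log units; within the scatter) and a 1.3-fold higher number from compound 1 to compound 3 (0.12 log units; within the scatter) are both small steps, and compound 2 and compound 3 are nearer still to each other. In short, none of these three compounds can be told apart in this assay.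

Compound 4 `Cc1ccc(/C=N/NC(=O)c2oc3nc(-c4cccs4)cc(C(F)(F)F)c3c2N)cc1` has not yet been measured. Against compound 2 the change is a group of 9 heavy atoms (8 carbon, 1 nitrogen; one six-membered aromatic ring of carbon only) in place of one carbon atom, on an amide-type nitrogen. Among the measured compounds shown here, the one measured step that bears on this is the step from compound 1 to compound 3, where a closely related group, carrying chlorine rather than methyl on its ring, replaced the same methyl: a 1.3-fold higher number from compound 1 to compound 3 (0.12 log units; within the scatter). On that basis no step beyond the scatter is expected in this assay. Compound 4 is therefore estimated at 85000 nM, with a range from 40000 nM to 180000 nM, which means an expected step of a 1.1-fold higher number from compound 2 to compound 4 (0.05 log units; within the scatter).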

Compound 4, half-maximal inhibitory concentration: 78000 nM
For compound 4 the middle estimate is 1.1-fold (0.04 log units) above the measured one; the range from low to high includes it.
By their numbers in this assay, from the lowest: compounds 1, 2, 4 and 3 (each within the scatter of the next).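

In this assay, putting the larger group with its six-membered aromatic ring in place of methyl on the amide-type nitrogen gives a 1.0-fold higher number from compound 2 to compound 4 (0.02 log units; within the scatter). The earlier compounds shown here showed this kind of change only with phenyl on the shared core and chlorine on the group's ring, whereas here, with thiophen-2-yl on the core and methyl on that ring, the step again stays within the scatter, so across these two pairs the exchange at this nitrogen has no readable effect. No measurement is available that would explain this outcome.

The compounds shown leave open whether an amine or a carboxylic acid on that ring would give a step beyond the scatter. They also leave open what a longer chain in place of methyl on the nitrogen would do.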